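This account rests on a few compounds, and the source may have more. Where it says the series, first, only, none or still open, it means among the compounds named here.

Of the compounds shown here, three from this series have been tested in a functional assay on HCT-116 cells (Homo sapiens) for antiproliferative activity, read by CCK-8 assay, with a stated time of 72 h, tested at 2 uM; on this read-out higher numbers stand for a stronger effect at the one concentration tested and lower numbers for a weaker effect. Compound 1 `Nc1ccccc1NC(=O)/C=C/c1ccc(Cn2cnc3c(Nc4ccccc4)nc(Cl)nc32)cc1` gives 7.75% in this assay. Compound 2 `CCCCn1cnc2c(Nc3ccccc3)nc(NCOCc3ccc(/C=C/C(=O)Nc4ccccc4N)cc3)nc21` gives 6.58% in this assay. Compound 3 `Nc1ccccc1NC(=O)c1ccc(Cn2cnc3c(Nc4cccc(OC(F)(F)F)c4)nc(Cl)nc32)cc1` gives 1.6% in this assay. All three numbers are small, and compound 2 sits close to both of its companions: the gap to compound 1 and the gap to compound 3 each lie within the usual scatter of repeated measurements, so nothing separates the three in a meaningful way.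

Compound 4 `CCCCn1cnc2c(Nc3cccc(Cl)c3)nc(NCOCc3ccc(/C=C/C(=O)Nc4ccccc4N)cc3)nc21` has not yet been measured. It differs from compound 2 in one place only: chloro in place of hydrogen on an aromatic carbon. Among the compounds with values here, no comparable pair among the measured compounds shows what such a change does here, so there is no measured step to lean on. Given that compound 1, compound 2 and compound 3 all sit close together, the step from compound 2 to compound 4 is expected to be a number 0.4 percentage points higher from compound 2 to compound 4 (within the scatter) in this assay, that is, nothing beyond the scatter. Compound 4 is therefore estimated to give about 7%, somewhere between 0% and 18%.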

Compound 4, a percentage reported as inhibition, at one concentration (the size of the read-out at that concentration, not a potency): 4.76%
Compound 4: middle estimate off by 2.2 percentage points, on the high side; measured number inside the range.
By their numbers in this assay, from the lowest: compounds 3, 4, 2 and 1 (each within the scatter of the next).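

In this assay, within the data shown here, the swap of anilino for (3-chlorophenyl)amino gives a number 1.8 percentage points lower from compound 2 to compound 4 (within the scatter) and is the first single-place change that can be read. On this evidence, the ring carbon carrying the chloro tolerates that atom in place of hydrogen, with compound 2 and compound 4 not told apart by this measurement. The pair cannot show a real effect of the chloro here, since both compounds have small numbers at the one concentration tested and any modest effect would be lost in the scatter.

From the compounds shown here alone, it remains open whether fluoro, methoxy or a trifluoromethyl group at this same carbon, or chloro on another carbon of this ring, would move the number beyond the scatter. Nothing measured here speaks to what lies behind this small step.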